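Removing a methyl from a weak inhibitor of an enzyme

A few compounds are considered here, and "the series" means these few. Any claim that something is new, unique, unknown or untested is made for them only; others in the source may bear on it.

This study looks at two measured compounds and one that is not yet measured, all tested in an assay for inhibition of Indoleamine 2,3-dioxygenase 1 (Homo sapiens), read by spectrophotometry, with a stated time of 180 min, tested at 1 uM; a lower number here means a weaker effect, a higher number a stronger effect of the compound at the concentration tested. Compound 1, `O=C(CNc1cc(Br)cc2[nH]ncc12)NC1CCOCC1`, gives 4% in this assay. Compound 2, `Cc1nc(NCc2ccc(C(=O)O)cc2)c2cn[nH]c2n1`, gives 3% in this assay. On these two numbers compound 2 sits at the bottom, but compound 1 is only a single point away and that gap is within the scatter, so the two cannot be told apart: both show almost no effect at the concentration tested.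

Compound 3, `O=C(O)c1ccc(CNc2ncnc3[nH]ncc23)cc1`, differs from compound 2 in one place: hydrogen in place of methyl on an aromatic carbon. Within the data shown here, no pair of measured compounds that differ in one place is available, so nothing measured tells how such a small change moves the read-out. Because compound 2 gives 3%, which is already close to no effect, the expected step of a number 1 percentage points higher from compound 2 to compound 3 (within the scatter) is none beyond the scatter. Compound 3 is therefore estimated to give 4%, within a range from -6% to 14%.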

Compound 3, a percentage reported as inhibition, at one concentration (the size of the read-out at that concentration, not a potency): 3%
Compound 3: the middle estimate sits 1 percentage points above what was measured; the range from low to high includes it.
By their numbers in this assay, from the lowest: compounds 2, 3 and 1 (each within the scatter of the next).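

Among these compounds, this is the first measured step at this position: leaving hydrogen where the methyl stood, on the aromatic carbon between two ring nitrogen atoms, gives no change at the digits printed from compound 2 to compound 3 (within the scatter) in this assay, so the methyl is not needed for the small read-out seen here. Compounds at this level show almost no effect at the concentration tested, so the step says little about what the methyl would do in a compound with a clear effect. Nothing available here explains the result.

Still open, going by these compounds, is whether a different group on this carbon, such as an amine, a chlorine atom or a longer chain like propyl, would lift the read-out clear of the scatter. Also open, on these data alone, is whether changing another part of compound 3, for example replacing its carboxylic acid with a methyl ester, would move the number at all.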